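Nitro Group on the Benzyl Ring of a Lactam Amidine

This account rests on a few compounds, and the source may have more. Where it says the series, first, only, none or still open, it means among the compounds named here.

Of the compounds shown here, three sharing one core have been measured in a functional assay on SH-SY5Y cells (Homo sapiens) for cytotoxicity, read by MTT assay, with stated times of 8 h, 30 min and 12 h, tested at 5 uM; a lower number here means a weaker effect, a higher number a stronger effect of the compound at the concentration tested. Compound 1 `N=C(NCc1ccccc1)[C@@H]1CCC(=O)N1Cc1ccccc1` gives 20.7%. Compound 2 `COc1ccc(CNC(=N)[C@@H]2CCC(=O)N2Cc2ccccc2)cc1` gives 19.5%, and the change hydrogen in place of methoxy on an aromatic carbon yields a number 1.2 percentage points lower from compound 1 to compound 2 (within the scatter). Compound 3 `COc1ccc(CNC(=N)[C@@H]2CCC(=O)N2Cc2ccccc2[N+](=O)[O-])cc1` gives 25.4%; here the change is nitro in place of hydrogen on an aromatic carbon, and it produced a number 5.9 percentage points higher from compound 2 to compound 3 (within the scatter).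

Compound 4 `N=C(NCc1ccccc1)[C@@H]1CCC(=O)N1Cc1ccc([N+](=O)[O-])cc1` has not yet been measured. It differs from compound 1 by nitro in place of hydrogen on an aromatic carbon. Among the measured compounds shown here, this is the same kind of change as the one from compound 2 to compound 3, but not the same: there the nitro group sits ortho to a large group, whereas in compound 4 it sits para to a large group. The two cores differ as described by hydrogen in place of methoxy on an aromatic carbon.

Against that background, the step from compound 1 to compound 4 in this assay is expected to be a number 3.3 percentage points higher from compound 1 to compound 4 (within the scatter), resting on the similar-sized step a number 5.9 percentage points higher from compound 2 to compound 3 (within the scatter). Compound 4 is therefore estimated at 24%, with a likely range from 14% to 34%.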

Compound 4, a percentage reported as activity, at one concentration (the size of the read-out at that concentration, not a potency): 25.6%
Compound 4: the middle estimate sits 1.6 percentage points below what was measured; the range from low to high includes it.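

In this assay, putting a nitro group on an aromatic carbon gives a number 4.9 percentage points higher from compound 1 to compound 4 (within the scatter). Set beside the earlier case, the same change behaves alike on the two cores: the same change on two cores in this assay, a number 5.9 percentage points higher (within the scatter) from compound 2 to compound 3 and a number 4.9 percentage points higher (within the scatter) from compound 1 to compound 4, 1 percentage points apart, within the scatter of two such steps

So the change carries from one core to the other with no visible difference, but each step on its own lies within the usual scatter, so this does not show that the nitro group alters the read-out at all, and the group sits para to a large group only in compound 4, so the part played by its place on the ring cannot be separated from that of the core.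

The compounds shown leave open whether an amine or a carboxylic acid in the place of the nitro group would move the read-out beyond the scatter. They also leave open how a nitro group would behave on the core of compound 1 at the place it holds in compound 3.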